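A Methyl on the Amine Nitrogen: Expectation for Compound 4

This account rests on a few compounds, and the source may have more. Where it says the series, first, only, none or still open, it means among the compounds named here.

Measured in an assay on a cell-free system (plasma) for inhibition of Dipeptidyl peptidase 4 (Rattus norvegicus), read by fluorescence; a lower number here means a stronger inhibitor, a higher number a weaker inhibitor:
Compound 1, `O=C([C@@H]1C[C@H](NCc2ccccc2)CN1)N1CCSC1`, gives 171 nM.
Compound 2, `N#Cc1ccc(CN[C@@H]2CN[C@H](C(=O)N3CCSC3)C2)cc1`, gives 34.3 nM.
Compound 3, `N#Cc1ccc(S(=O)(=O)N[C@@H]2CN[C@H](C(=O)N3CCSC3)C2)cc1`, reaches only the limit of this assay, > 300 nM, and no number.

Among the numbers shown, compound 2 stands lowest; compound 1 sits a 5.0-fold lower number from compound 1 to compound 2 (0.70 log units; beyond the scatter), so the gap between them is beyond the scatter. Compound 3 sits at a limit, (the limit of > 300 nM in this assay, at which 1 of the 3 values shown sits).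

Compound 4, `CN(Cc1ccc(C#N)cc1)[C@@H]1CN[C@H](C(=O)N2CCSC2)C1`, differs from compound 2 in one place: methyl in place of hydrogen on an amine nitrogen. Within the data shown here, none of the measured steps bears directly on this change. Among the measured compounds shown here, the one measured step, a 5.0-fold lower number from compound 1 to compound 2 (0.70 log units; beyond the scatter), concerns an aromatic substituent and not the amine nitrogen, and compound 3 replaces the whole benzylamine and reaches only a limit. The evidence therefore gives no direction for adding a methyl to the amine nitrogen, and a step within the scatter, in either direction, is expected.

For compound 4 in this assay the estimate is 55 nM, with a range from 18 nM to 200 nM, which means an expected step of a 1.6-fold higher number from compound 2 to compound 4 (0.21 log units; within the scatter).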

Compound 4, half-maximal inhibitory concentration: 13.6 nM
The estimate for compound 4 lay 4.0-fold (0.61 log units) above the measured number, outside the stated range (below it).
By their numbers in this assay, from the lowest: compound 4; then compound 2; then compound 1. At a limit, above all of these: compound 3.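

In this assay there is a 2.5-fold lower number from compound 2 to compound 4 (0.40 log units; beyond the scatter) with methyl in place of hydrogen on the amine nitrogen, so this nitrogen, whose other neighbours are a saturated chain carbon and a saturated ring carbon, takes an added group with no loss here. The earlier compounds shown here spoke only to the aromatic substituent and to replacing the whole benzylamine, whereas this step shows that the hydrogen on this nitrogen is not needed for a low number. Nothing shown gives a cause for this step.

Going by these compounds, it remains open whether a larger group on this nitrogen, such as an ethyl or an acetyl, would extend the step or reverse it. On these data alone, it is also open whether methyl would give a similar step without the nitrile on the aromatic ring.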